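The compounds below may be only part of what the source reports. "The series", "measured", "known", "first", "only" and "open" are said of these compounds alone.

Compound 1 `CC(=O)Nc1ccc(S(=O)(=O)NNC(=O)c2cccnc2Nc2ccc(Cl)cc2)cc1` was tested in a functional assay on MDA-MB-231 cells (Homo sapiens) for antiproliferative activity; on this read-out lower numbers stand for stronger inhibition of growth and higher numbers for weaker inhibition of growth. In this assay compound 1 gives > 100000 nM, which is a limit of the assay and not a number. Compound 1 therefore stands at the limit of > 100000 nM in this assay, at which 2 of the 2 values shown sit. Compound 2 `O=C(NNS(=O)(=O)c1ccc(F)cc1)c1cccnc1Nc1ccc(Cl)cc1Cl` gives > 100000 nM in this assay, likewise a limit. Compound 3 `O=C(NNS(=O)(=O)c1ccc(Cl)cc1Cl)c1cccnc1Nc1ccc(Cl)cc1` is not yet measured in this assay; it differs from compound 1 by 2,4-dichlorophenyl in place of 4-acetamidophenyl on a sulfonyl sulfur. Going by the values given here, no step between measured compounds exists, so the expected change is none beyond the scatter. Compound 3 is expected to give 100000 nM, within 20000 nM to 300000 nM, most likely again a limit. The expected step from compound 1 to compound 3 is a number no higher from compound 1 to compound 3 (the limit leaves the size open).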

Compound 3, concentration for total growth inhibition: 50100 nM
The estimate for compound 3 lay 2.0-fold (0.30 log units) above the measured number, within the range that was stated.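

In this assay, replacing 4-acetamidophenyl with 2,4-dichlorophenyl gives an at least 1.9-fold lower number from compound 1 to compound 3 (0.30 log units; that floor lies within the scatter). This position can therefore carry a group that yields a real number rather than a limit, although the gain may still be no larger than the scatter. Its true size stays unknown, since the other values remain limits: the limit of > 100000 nM in this assay, at which 2 of the 3 values shown sit.

The compounds shown leave open whether both chlorines matter, as a single chlorine on this phenyl ring would test. They also leave open how an amine or a carboxylic acid on that ring would behave.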